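Swapping the sulfonyl aryl group on a fluorinated core

The source may report more compounds than this note shows. Statements on the series, on what has been measured and on what is new or still open speak of the compounds shown alone.

Three compounds measured in an assay on isolated protein for displacement of a labelled ligand from metabotropic glutamate receptor 5 (Homo sapiens), with a stated time of 60 min, tested at 1 uM (a higher number here means more inhibition at the concentration tested (going by the name of the read-out), a lower number less inhibition), share a common arrangement in which a sulfonyl sulfur carries an aromatic ring. Compound 1 `COc1ccc2ncc(S(=O)(=O)c3ccc(Cl)cc3)c(N3CCC(C)CC3)c2c1` gives 91% in this assay. Compound 2 `COc1ccc2ncc(S(=O)(=O)c3cccc(C#N)c3)c(N3CCC(C)CC3)c2c1` gives 90%, and compound 3 `CC1CCN(c2c(S(=O)(=O)c3cccc(C#N)c3)cnc3cc(F)ccc23)CC1` gives 92%; the three numbers lie within the usual scatter of one another, so the inhibition in this assay is level across them.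

The change from compound 2 to compound 1 is 4-chlorophenyl in place of 3-cyanophenyl on a sulfonyl sulfur, and it moved the read-out by a number 1 percentage points higher from compound 2 to compound 1 (within the scatter). Compound 3 carries a different core from compound 2; how the two cores differ is not broken down here.

Compound 4 `CC1CCN(c2c(S(=O)(=O)c3ccc(Cl)cc3)cnc3cc(F)ccc23)CC1` has not yet been measured. Within the data shown here, it is related to compound 3 by 4-chlorophenyl in place of 3-cyanophenyl on a sulfonyl sulfur, which is the same change as the one made from compound 2 to compound 1, made on the core of compound 3. Because that earlier step of a number 1 percentage points higher from compound 2 to compound 1 (within the scatter) stayed within the scatter, the step from compound 3 to compound 4 is expected to be about no change at the digits printed from compound 3 to compound 4 (within the scatter), on the sole basis of this one precedent. Compound 4 is therefore estimated to reach about 92% in this assay.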

Compound 4, a percentage reported as inhibition, at one concentration (the size of the read-out at that concentration, not a potency): 90%
Compound 4: middle estimate off by 2 percentage points, on the high side; low and high end bracket the measured number.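

In this assay, putting 4-chlorophenyl in place of 3-cyanophenyl on the sulfonyl sulfur of the core of compound 3 gave a number 2 percentage points lower from compound 3 to compound 4 (within the scatter). Set beside the earlier step, the change reads the same on both cores: the same change on two cores in this assay, a number 1 percentage points higher (within the scatter) from compound 2 to compound 1 and a number 2 percentage points lower (within the scatter) from compound 3 to compound 4, 3 percentage points apart, within the scatter of two such steps This shows that the swap makes no readable difference to inhibition on these two cores at the one concentration tested, but it does not show that the two aryl groups are equivalent, since a percentage at a single concentration is not a potency, and two cores say nothing about any others.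

The compounds shown carry only 4-chlorophenyl or 3-cyanophenyl on the sulfonyl sulfur, so it remains open how an aromatic ring bearing a carboxylic acid or an amine, or a plain methyl group in place of the ring, would read in this assay. Also open, going by these compounds, is whether the four compounds differ in potency, a question that needs readings across a range of concentrations.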